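The compounds below may be only part of what the source reports. "The series", "measured", "known", "first", "only" and "open" are said of these compounds alone.

In an assay on CHO cells for displacement of a labelled ligand from transient receptor potential cation channel subfamily V member 1 (Rattus norvegicus) (on this read-out lower numbers stand for stronger inhibition and higher numbers for weaker inhibition), compound 1 `COc1cc(CNC(=S)NCC(COC(=O)C(C)(C)C)Cc2ccc(C(C)(C)C)cc2)c(Br)cc1O` gives 12.8 nM, and compound 2 `COc1cc(CNC(=S)NCC(COC(=O)C(C)(C)C)Cc2ccc(C(C)(C)C)cc2)c(I)cc1O` gives 13.3 nM. The two differ only by iodo in place of bromo on an aromatic carbon, a step that made a 1.0-fold higher number from compound 1 to compound 2 (0.02 log units; within the scatter). Compound 3 `COc1cc(CNC(=S)NC(CCc2ccc(C(C)(C)C)cc2)COC(=O)C(C)(C)C)cc(Br)c1O` has the same atoms joined differently; how its core differs from that of compound 1 is not broken down here. In this assay compound 3 gives 143 nM. Compound 4 `COc1cc(CNC(=S)NC(CCc2ccc(C(C)(C)C)cc2)COC(=O)C(C)(C)C)cc(I)c1O` carries the same kind of change relative to compound 3, namely (iodo in place of bromo on an aromatic carbon), though the surroundings differ: in compound 2 the iodo sits ortho to a large group, meta to a hydroxy group and para to a methoxy group, whereas in compound 4 it sits ortho to a hydroxy group, meta to a large group and meta to a methoxy group. For compound 4 a step of a 1.0-fold higher number from compound 3 to compound 4 (0.01 log units; within the scatter) is expected, because the same kind of change gave a 1.0-fold higher number from compound 1 to compound 2 (0.02 log units; within the scatter). Compound 4 is therefore estimated at 145 nM, within a likely range from 70 nM to 300 nM.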

Compound 4, inhibition constant: 214 nM
Estimate against measurement, compound 4: 1.5-fold (0.17 log units) below; low and high end bracket the measured number.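

In this assay, putting iodo in place of bromo on the second core gave a 1.5-fold higher number from compound 3 to compound 4 (0.18 log units; within the scatter), so on this core the two halogens cannot be told apart. Going by these compounds alone, the swap carried over from one core to the other, with the two steps in agreement: the same change on two cores in this assay, a 1.0-fold higher number (0.02 log units; within the scatter) from compound 1 to compound 2 and a 1.5-fold higher number (0.18 log units; within the scatter) from compound 3 to compound 4, 1.4-fold (0.16 log units) apart, within the scatter of two such steps This rests on only two pairs, and as neither step goes beyond the scatter, it does not show that a step of clear size would carry over between these cores, or that this one would hold on any other core.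

Still open, from the compounds shown here alone, is what chloro, or a plain hydrogen in place of the halogen, would give on either core. Going by these compounds, an amine or a carboxylic acid at that ring position is equally open.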